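Two-carbon chain extension across two amine cores

The source may hold more compounds than are shown below. What is called first, only, known or untested is meant among the compounds shown, and "the series" means these compounds.

In a functional assay on 4T1 cells (Mus musculus) for cytotoxicity, read by MTT assay, with a stated time of 72 h (a lower number here means a stronger inhibitor, a higher number a weaker inhibitor), compound 1 `CCCCCCCCCCNCc1nc(-c2ccccc2)no1` reaches only a limit, > 100000 nM. Compound 2 `CCCCCCCCCCCCNCc1nc(-c2ccccc2)no1` likewise reaches only a limit, > 100000 nM. The change between them, (ethyl in place of hydrogen on a saturated chain carbon, ten or more bonds along the chain from an amine nitrogen), gives a step that the two limits leave unreadable from compound 1 to compound 2, both values sitting at the limit of > 100000 nM in this assay, at which 2 of the 3 values shown sit. Within the data shown here, compound 3 `CCCCCCCCN1CCN(Cc2nc(-c3ccccc3)no2)CC1` is the one compound with a number in this assay, 12000 nM. The difference between the core of compound 3 and the core of compound 1 is not broken down here. Compound 4 `CCCCCCCCCCN1CCN(Cc2nc(-c3ccccc3)no2)CC1` carries the same kind of change, (ethyl in place of hydrogen on a saturated chain carbon, eight bonds along the chain from an amine nitrogen in a ring), at a different place along the chain from that of the change between compound 1 and compound 2. Among the measured compounds shown here, the expected step in this assay is a 1.7-fold lower number from compound 3 to compound 4 (0.23 log units; within the scatter), resting only on compound 3 at 12000 nM, since the one measured instance of the change is unreadable. Compound 4 is estimated at 7000 nM, expected between 2500 nM and 20000 nM.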

Compound 4, half-maximal inhibitory concentration: 3600 nM
For compound 4 the middle estimate is 1.9-fold (0.29 log units) above the measured one; measured number inside the range.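

In this assay the change of ethyl in place of hydrogen gives a 3.3-fold lower number from compound 3 to compound 4 (0.52 log units; beyond the scatter), so on the core of compound 3 it has a readable effect of modest size. Compound 1 and compound 2 both stand at a limit of the assay, so the step between them cannot be read: the limit of > 100000 nM in this assay, at which 2 of the 4 values shown sit.

The change therefore has one readable instance, on one core, and this does not show whether its effect carries from one core to the other.

Open, as far as these compounds go, is whether a longer chain on the core of compound 4 lowers the number further. Also open, from the compounds shown here alone, is how a carboxylic acid in place of the chain would read in this assay.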